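A few compounds are considered here, and "the series" means these few. Any claim that something is new, unique, unknown or untested is made for them only; others in the source may bear on it.

Compound 1 `COc1cc(-c2nc(CO[C@@H]3O[C@H](CSc4ncn[nH]4)[C@H]4OC5(CCCC5)O[C@@H]34)no2)cc(OC)c1OC` gives 34000 nM in a functional assay on HBL-100 cells (Homo sapiens) for antiproliferative activity, read by sulforhodamine B assay, with a stated time of 48 h; a lower number here means a stronger inhibitor of growth, a higher number a weaker inhibitor of growth; compound 2 `O=[N+]([O-])c1ccc(-c2nc(CO[C@@H]3O[C@H](CO)[C@H]4OC5(CCCC5)O[C@@H]34)no2)cc1` gives 17000 nM; compound 3 `CC(=O)OC[C@H]1O[C@@H](OCc2noc(-c3ccc([N+](=O)[O-])cc3)n2)[C@@H]2OC3(CCCC3)O[C@@H]21` gives 23000 nM.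

Compound 3 stands second highest of the three numbers, within the scatter of both compound 2 and compound 1. Compound 4 `O=[N+]([O-])c1ccc(-c2nc(CO[C@@H]3O[C@H](CSc4ncn[nH]4)[C@H]4OC5(CCCC5)O[C@@H]34)no2)cc1` differs from compound 3 by (1H-1,2,4-triazol-5-yl)sulfanyl in place of acetoxy on a saturated chain carbon bound to a saturated ring carbon. Going by the values given here, no measured step covers this exchange. Among the compounds with values here, the only step on the same carbon, a 1.4-fold higher number from compound 2 to compound 3 (0.13 log units; within the scatter), was within the scatter, and compound 1, which already carries the entering group on a different aryl, sits within the scatter of compound 3. Compound 4 is therefore expected to show no step beyond the scatter, a 1.1-fold higher number from compound 3 to compound 4 (0.04 log units; within the scatter). Compound 4 is estimated at 25000 nM, with a range from 10000 nM to 60000 nM.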

Compound 4, concentration for 50% growth inhibition: 24000 nM
Compound 4: the middle estimate sits 1.0-fold (0.02 log units) above what was measured; the range from low to high includes it.
By their numbers in this assay, from the lowest: compounds 2, 3, 4 and 1 (each within the scatter of the next).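

In this assay, the saturated chain carbon bound to a saturated ring carbon now carries three groups, hydroxy, acetoxy and (1H-1,2,4-triazol-5-yl)sulfanyl, and no exchange among them leaves the scatter (a 1.0-fold higher number from compound 3 to compound 4 (0.02 log units; within the scatter); a 1.4-fold higher number from compound 2 to compound 4 (0.15 log units; within the scatter)). With that sulfanyl group in place, 4-nitrophenyl in place of 3,4,5-trimethoxyphenyl also stays within the scatter (a 1.4-fold lower number from compound 1 to compound 4 (0.15 log units; within the scatter)). No measurement here bears on why these numbers stay so close.

Going by these compounds, whether an amine, a carboxylic acid or a longer chain on that carbon would give a step beyond the scatter remains open.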